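Adding a Methyl to the Side Chain of Compound 3

The source may hold more compounds than are shown below. What is called first, only, known or untested is meant among the compounds shown, and "the series" means these compounds.

Of the compounds shown here, three have been measured in a functional assay on A549 cells (Homo sapiens) for antiproliferative activity, read by MTT assay, with a stated time of 72 h; on this read-out higher numbers stand for weaker inhibition and lower numbers for stronger inhibition. Compound 1 `COc1cc(N(C)CCN(C)C)c(NC(=O)/C=C\C(C)C)cc1Nc1nccc(-c2cn(C)c3ccccc23)n1` gives 612 nM, compound 2 `C=C(Cl)C(=O)Nc1cc(Nc2nc(C)cc(-c3cn(C)c4ccccc34)n2)c(OC)cc1N(C)CCN(C)C` gives 1730 nM, and compound 3 `CC/C=C\C(=O)Nc1cc(Nc2nc(C)cc(-c3cn(C)c4ccccc34)n2)c(OC)cc1N(C)CCN(C)C` gives 1090 nM. Compound 3 stands second highest of these three numbers; its nearest neighbour is compound 2 and its furthest is compound 1, and both gaps lie within the scatter. Among the measured compounds shown here, the one recorded step, a 1.6-fold lower number from compound 2 to compound 3 (0.20 log units; within the scatter), exchanges the group on the carbonyl carbon. Compound 4 `COc1cc(N(C)CCN(C)C)c(NC(=O)/C=C\C(C)C)cc1Nc1nc(C)cc(-c2cn(C)c3ccccc23)n1` differs from compound 3 by methyl in place of hydrogen on a saturated chain carbon bound to a double-bonded chain carbon and a saturated chain carbon. For the measured compounds named here, no measured step carries this exact change, so the expectation rests on compound 3, which gives 1090 nM, read beside compound 1, which carries the same 3-methylbut-1-en-1-yl group and gives 612 nM. Compound 4 is therefore expected to give 900 nM, between 400 nM and 2000 nM, an expected step of a 1.2-fold lower number from compound 3 to compound 4 (0.08 log units; within the scatter) in this assay.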

Compound 4, half-maximal inhibitory concentration: 1070 nM
Estimate against measurement, compound 4: 1.2-fold (0.08 log units) below, within the range that was stated.
By their numbers in this assay, from the lowest: compounds 1, 4, 3 and 2 (each within the scatter of the next, the first and the last beyond it).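

In this assay methyl in place of hydrogen on the saturated chain carbon, which turns but-1-en-1-yl into 3-methylbut-1-en-1-yl, leaves the number essentially unchanged (a 1.0-fold lower number from compound 3 to compound 4 (0.01 log units; within the scatter)). The two other new steps also stay within the scatter: 3-methylbut-1-en-1-yl in place of 1-chloroethenyl on the carbonyl carbon (a 1.6-fold lower number from compound 2 to compound 4 (0.21 log units; within the scatter)), and methyl in place of hydrogen on an aromatic carbon (a 1.7-fold higher number from compound 1 to compound 4 (0.24 log units; within the scatter)). No measurement offers an explanation for these small steps. From the compounds shown here alone, whether a larger group at this saturated chain carbon, such as phenyl or a dimethylamino group, would move the number beyond the scatter remains open.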